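Shifting the halogen on the phenylpropyl oxime chain

The compounds below may be only part of what the source reports. "The series", "measured", "known", "first", "only" and "open" are said of these compounds alone.

Measured compounds in this assay:
Compound 1 `O=c1[nH]/c(=N\OCCCCc2ccccc2)ccn1[C@@H]1O[C@H](COP(=O)(O)OP(=O)(O)OP(=O)(O)O)[C@@H](O)[C@H]1O` gives 214 nM.
Compound 2 `O=c1[nH]/c(=N\OCCCc2cccc(F)c2)ccn1[C@@H]1O[C@H](COP(=O)(O)OP(=O)(O)OP(=O)(O)O)[C@@H](O)[C@H]1O` gives 190 nM.
Compound 3 `O=c1[nH]/c(=N\OCCCc2ccc(F)cc2)ccn1[C@@H]1O[C@H](COP(=O)(O)OP(=O)(O)OP(=O)(O)O)[C@@H](O)[C@H]1O` gives 547 nM.

All three share the same triphosphate-bearing core and differ only in the aromatic end of the oxime side chain. In a functional assay on 1321-N1 cells for agonist activity at P2Y purinoceptor 2 (Homo sapiens), read by scintillation counting and inositol phosphate accumulation (on this read-out lower numbers stand for an effect already at smaller amounts and higher numbers for an effect only at larger amounts of compound), compound 3 shows the highest number of the three; its step from compound 1 is a 2.6-fold higher number from compound 1 to compound 3 (0.41 log units; beyond the scatter), and from compound 2 it is a 2.9-fold higher number from compound 2 to compound 3 (0.46 log units; beyond the scatter), while compound 1 and compound 2 are separated by a 1.1-fold lower number from compound 1 to compound 2 (0.05 log units; within the scatter).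

Compound 4 `O=c1[nH]/c(=N\OCCCc2cccc(I)c2)ccn1[C@@H]1O[C@H](COP(=O)(O)OP(=O)(O)OP(=O)(O)O)[C@@H](O)[C@H]1O` has not yet been measured. Its difference from compound 3 is 3-iodophenyl in place of 4-fluorophenyl on a saturated chain carbon, three bonds along the chain from an oxygen. Two of the measured steps bear on this change. The move from a 4-fluorophenyl to a 3-fluorophenyl, compound 3 to compound 2, lowered the number beyond the scatter, which suggests that the change of ring position in compound 4 may do likewise. Among the compounds with values here, no measured pair tells what exchanging fluorine for iodine does, so that part of the change carries no direction from the data.

On this basis compound 4 is expected to return a lower number than compound 3, with the step estimated at a 2.9-fold lower number from compound 3 to compound 4 (0.46 log units; beyond the scatter). The estimate for compound 4 in this assay is 190 nM, with a range from 60 nM to 600 nM.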

Compound 4, half-maximal effective concentration: 325 nM
Beside the measured number, compound 4's estimate is 1.7-fold (0.23 log units) below it; measured number inside the range.
By their numbers in this assay, from the lowest: compounds 2, 1, 4 and 3 (each within the scatter of the next, the first and the last beyond it).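

In this assay, within the data shown here, the pair of compound 2 and compound 4 gives the first direct reading of iodo in place of fluoro on an aromatic carbon, and that exchange produces a 1.7-fold higher number from compound 2 to compound 4 (0.23 log units; within the scatter), so the two halogens cannot be told apart on the 3-substituted phenyl end. The step to the 4-fluorophenyl compound, a 1.7-fold lower number from compound 3 to compound 4 (0.23 log units; within the scatter), and the step from the unhalogenated chain, a 1.5-fold higher number from compound 1 to compound 4 (0.18 log units; within the scatter), are also within the scatter, which leaves compound 4 unresolved from all three earlier compounds even though compound 2 and compound 3 stand apart by a 2.9-fold higher number from compound 2 to compound 3 (0.46 log units; beyond the scatter). Nothing shown here accounts for these steps.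

With 3-iodophenyl as the only iodo-bearing end, the compounds shown leave open whether moving iodo around the ring would separate two compounds in the way that moving fluoro separates compound 2 from compound 3. They also leave open how a chloro, bromo or methoxy group, or a carboxylic acid, would read on the same ring with the shared core and chain unchanged.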